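Amide-nitrogen variation on a shared core: notes toward compound 4

The source may report more compounds than this note shows. Statements on the series, on what has been measured and on what is new or still open speak of the compounds shown alone.

Compound 3 `COc1ccc2c(=O)c(/C=C/C(=O)NCc3ccccc3F)coc2c1` carries a 2-fluorobenzyl group on an amide-type nitrogen. In a functional assay on HeLa cells (Homo sapiens) for inhibition, read by MTT assay, with a stated time of 48 h (on this read-out lower numbers stand for stronger inhibition and higher numbers for weaker inhibition), compound 3 gives only a limit, > 100000 nM. Compound 1 `COc1ccc2c(=O)c(/C=C/C(=O)Nc3ccccc3)coc2c1`, the phenyl amide, also gives a limit in this assay, > 100000 nM. Compound 2 `COc1ccc2c(=O)c(/C=C/C(=O)NCc3ccc(F)cc3)coc2c1`, with 4-fluorobenzyl, likewise gives a limit, > 100000 nM. The steps a step that the two limits leave unreadable from compound 1 to compound 2, a step that the two limits leave unreadable from compound 1 to compound 3 and a step that the two limits leave unreadable from compound 2 to compound 3 cannot be sized, since (the limit of > 100000 nM in this assay, at which 3 of the 3 values shown sit). Compound 4 `COc1ccc2c(=O)c(/C=C/C(=O)Nc3ccc(F)cc3)coc2c1` differs from compound 3 by 4-fluorophenyl in place of 2-fluorobenzyl on an amide-type nitrogen. Compound 4 shares with compound 1 an aryl group directly on the amide-type nitrogen. The step of a number no higher from compound 3 to compound 4 (the limit leaves the size open) is therefore expected to be none beyond the scatter, with compound 4 most likely again reported only as a limit. Compound 4 is estimated at 100000 nM, within 40000 nM to 250000 nM.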

Compound 4, half-maximal inhibitory concentration: 9680 nM
Estimate against measurement, compound 4: 10-fold (1.01 log units) above; measured number outside the range, below it.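

On the amide-type nitrogen in this assay, fluoro in place of hydrogen on an aromatic carbon gives an at least 10-fold lower number from compound 1 to compound 4 (1.01 log units; beyond the scatter) and so shows that this position can respond to a single-atom change. Compound 2 and compound 3 also carry fluoro, yet 4-fluorophenyl in place of their fluorobenzyl groups gives an at least 10-fold lower number from compound 2 to compound 4 (1.01 log units; beyond the scatter) and an at least 10-fold lower number from compound 3 to compound 4 (1.01 log units; beyond the scatter), so fluoro alone does not account for the readable value. Only compound 4 gives a number; the others remain limits: the limit of > 100000 nM in this assay, at which 3 of the 4 values shown sit.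

Going by these compounds, whether chloro or methoxy in place of the fluoro on the phenyl ring would give a readable value remains open. So does the effect of 2-fluorophenyl directly on the amide-type nitrogen.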